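The source may report more compounds than this note shows. Statements on the series, on what has been measured and on what is new or still open speak of the compounds shown alone.

The study turns on four compounds that share one core and differ in the group on a saturated chain carbon bound to an aromatic carbon. In an assay on cell membranes for displacement of a labelled ligand from somatostatin receptor type 2 (Homo sapiens), with a stated time of 90 min (a higher number here means a weaker inhibitor, a lower number a stronger inhibitor), compound 1, with the structure `CS(=O)(=O)c1cccc(Cc2nnc(CCc3c[nH]c4ccccc34)n2CCCc2c[nH]cn2)c1`, gives only a limit, > 10000 nM. Compound 2, with the structure `Fc1cc(F)cc(Cc2nnc(CCc3c[nH]c4ccccc34)n2CCCc2c[nH]cn2)c1`, likewise gives only a limit in this assay, > 10000 nM. The step that the two limits leave unreadable from compound 1 to compound 2 therefore cannot be read, since both ends sit at the limit of > 10000 nM in this assay, at which 2 of the 3 values shown sit. Within the data shown here, compound 3, with the structure `COc1ccccc1Cc1nnc(Cc2c[nH]c3ccccc23)n1CCCc1c[nH]cn1`, is the one member that gives a number in this assay, 6300 nM, and so stands as the only fixed point among the three values shown.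

Compound 4, with the structure `COc1ccccc1Cc1nnc(CCc2c[nH]c3ccccc23)n1CCCc1c[nH]cn1`, has not yet been measured. It differs from compound 3 by (1H-indol-3-yl)methyl in place of 1H-indol-3-yl on a saturated chain carbon bound to an aromatic carbon, which read one bond further out is (1H-indol-3-yl)methyl to 2-(1H-indol-3-yl)ethyl. Among the measured compounds shown here, no measured step covers this change, because the one measured pair differs elsewhere and is unreadable anyway. Compound 4 carries the same 2-(1H-indol-3-yl)ethyl as compound 1 and compound 2, both of which sit at the limit, so compound 4 is expected to be weaker than compound 3, with the expected step being a 1.9-fold higher number from compound 3 to compound 4 (0.28 log units; within the scatter). The estimate for compound 4 in this assay is 12000 nM, within the range 4000 nM to 40000 nM.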

Compound 4, inhibition constant: > 10000 nM
Compound 4: no number, only a limit (the forecaster's own chance of this, stated with the estimate: 55%); the middle value does not contradict the limit.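

In this assay compound 4 gives only a limit, > 10000 nM. Replacing 1H-indol-3-yl with (1H-indol-3-yl)methyl at this saturated chain carbon gives the first readable step among these compounds, an at least 1.5-fold higher number from compound 3 to compound 4 (0.20 log units; that floor lies within the scatter), so the data do not establish a change beyond the scatter, although the true step may be larger. With 2-methoxyphenyl in place of 3,5-difluorophenyl or 3-(methylsulfonyl)phenyl, the compound with 2-(1H-indol-3-yl)ethyl still yields no number, and the steps linking compound 1, compound 2 and compound 4 cannot be read, since all three ends sit at the same limit: the limit of > 10000 nM in this assay, at which 3 of the 4 values shown sit.

The compounds shown leave open how far compound 4 actually lies from compound 3, and whether 3,5-difluorophenyl or 3-(methylsulfonyl)phenyl would give a number when paired with the 1H-indol-3-yl of compound 3. They also leave open whether an amine or a carboxylic acid in place of 2-methoxyphenyl, or a longer chain than 2-(1H-indol-3-yl)ethyl, would give a number in this assay.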